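A methyl on the phenyl ring of a cytotoxic benzoxazole

The source may hold more compounds than are shown below. What is called first, only, known or untested is meant among the compounds shown, and "the series" means these compounds.

Compound 1 `O=Cc1c(O)ccc2oc(-c3cccc4ccccc34)nc12` and compound 2 `O=Cc1c(O)ccc2oc(-c3cccc(Cl)c3)nc12` share a core with compound 3 `CC(=O)c1c(O)ccc2oc(-c3ccccc3)nc12`, which carries an acetyl group where the other two carry an aldehyde. In a functional assay on A549 cells (Homo sapiens) for cytotoxicity, read by MTT assay, with a stated time of 48 h (a higher number here means a weaker inhibitor, a lower number a stronger inhibitor), compound 1 gives 28400 nM and compound 2 gives 1870 nM. Compound 3 stands apart from both: in this assay compound 3 returns only the limit > 30000 nM, a value that marks the edge of the assay rather than a measured number, as noted in the limit of > 30000 nM in this assay, at which 1 of the 3 values shown sits. Compound 3 is therefore the weakest of the three shown, without a figure to say by how much.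

Compound 4 `CC(=O)c1c(O)ccc2oc(-c3ccccc3C)nc12` differs from compound 3 by methyl in place of hydrogen on an aromatic carbon, placed ortho to a large group. No measured pair in this set shows what such a change does, so the account can only reason from the starting point. Since compound 3 sits at the limit, a step within the scatter or a modest move in either direction would still be expected to leave compound 4 near the edge of the assay, with the estimated step from compound 3 to compound 4 being a number no higher from compound 3 to compound 4 (the limit leaves the size open). Compound 4 is accordingly expected to give about 30000 nM in this assay, most likely between 10000 nM and 100000 nM.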

Compound 4, half-maximal inhibitory concentration: 20100 nM
For compound 4 the middle estimate is 1.5-fold (0.17 log units) above the measured one, within the range that was stated.
By their numbers in this assay, from the lowest: compound 2; then compounds 4 and 1 (each within the scatter of the next). At a limit, above all of these: compound 3.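

Compound 4 gives the acetyl-bearing compounds shown their first measured number rather than a limit, and so the first reading of what happens at this place on the ring. In this assay, methyl in place of hydrogen on an aromatic carbon, ortho to a large group, gives an at least 1.4-fold lower number from compound 3 to compound 4 (0.17 log units; that floor lies within the scatter), so the direction of the change can be read, and a methyl here does not push the number beyond the reach of the assay. Only a floor can be given for the size of this step, and it may be larger, because compound 3 stands at a limit and not at a number: the limit of > 30000 nM in this assay, at which 1 of the 4 values shown sits.

The compounds shown leave open whether a different group at this same place, such as a methoxy group, an amine or a longer chain such as ethyl, would move the number further, and whether a methyl on another carbon of the same ring would act as this one does. They also leave open whether the same methyl would change the number when an aldehyde stands in place of the acetyl group.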